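A few compounds are considered here, and "the series" means these few. Any claim that something is new, unique, unknown or untested is made for them only; others in the source may bear on it.

Compound 3 `N#Cc1cnc(NCc2cnccc2C(F)(F)F)cc1NC[C@H]1CC[C@@H](O)CC1` gives the lowest of the three numbers recorded in an assay on isolated protein for inhibition of protein kinase C delta type (Homo sapiens), read by TR-FRET, with a stated time of 2 h (on this read-out lower numbers stand for stronger inhibition and higher numbers for weaker inhibition), with compound 3 at 500 nM. Compound 1 `N#Cc1cnc(NCc2cnccc2C(F)(F)F)cc1NC[C@H]1C[C@@H](O)C1` gives 4200 nM, and compound 2 `N#Cc1cnc(NCc2cnccc2C(F)(F)F)cc1N[C@H]1CC[C@@H](O)CC1` gives 4500 nM; the step of a 1.1-fold higher number from compound 1 to compound 2 (0.03 log units; within the scatter) keeps these two within the usual scatter of each other. The steps of an 8.4-fold lower number from compound 1 to compound 3 (0.92 log units; beyond the scatter) and a 9.0-fold lower number from compound 2 to compound 3 (0.95 log units; beyond the scatter) set compound 3 apart from both.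

Compound 4 `CO[C@H]1CC[C@@H](CNc2cc(NCc3cnccc3C(F)(F)F)ncc2C#N)CC1` differs from compound 3 by methyl in place of hydrogen on an oxygen on a saturated carbon. Among the compounds with values here, none of the measured steps concerns this oxygen: each of them alters the ring or the chain that carries it, so no measured step bears directly on the change from compound 3 to compound 4, and the data give no guide to its size. Compound 4 is therefore expected to stay close to compound 3, with a step of a 1.4-fold higher number from compound 3 to compound 4 (0.15 log units; within the scatter) expected, which is no step beyond the scatter or at most a slight one toward a higher number. The estimate for compound 4 in this assay is 700 nM, within a range from 250 nM to 2000 nM.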

Compound 4, half-maximal inhibitory concentration: 5000 nM
For compound 4 the middle estimate is 7.1-fold (0.85 log units) below the measured one; the measured number lies above the stated range.
By their numbers in this assay, from the lowest: compound 3; then compounds 1, 2 and 4 (each within the scatter of the next).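

In this assay the hydroxy of compound 3 turns out not to be interchangeable with methoxy: the step to methoxy is a 10-fold higher number from compound 3 to compound 4 (1.00 log units; beyond the scatter), about as large as the steps that altered the ring or the chain. The steps of a 1.1-fold higher number from compound 2 to compound 4 (0.05 log units; within the scatter) and a 1.2-fold higher number from compound 1 to compound 4 (0.08 log units; within the scatter) are both within the scatter, so among these compounds only the (4-hydroxycyclohexyl)methyl group, with its hydrogen on the oxygen intact, stands apart. Nothing at hand explains this loss.

The compounds shown leave open whether an amine or a carboxylic acid on that saturated carbon would hold the number of compound 3, and how an ethoxy group would compare. They also leave open whether methoxy would shift the number on the other two side chains.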